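The source may report more compounds than this note shows. Statements on the series, on what has been measured and on what is new or still open speak of the compounds shown alone.

In a physicochemical assay for solubility, at pH 7.4 (a higher number here means a more soluble compound, a lower number a less soluble compound), compound 1 `O=C(N[C@H]1CN(S(=O)(=O)c2ccccc2)C[C@@H]1C(=O)N[C@H]1CCCNC1)c1cc(-c2ccccc2Cl)on1` gives 12000 nM and compound 2 `CN(C(=O)[C@H]1CN(S(=O)(=O)c2ccccc2)C[C@@H]1NC(=O)c1cc(-c2ccccc2Cl)on1)[C@H]1CCCNC1` gives 113000 nM, the higher of the two numbers. Compound 3 `O=CN1CCC[C@H](NC(=O)[C@H]2CN(S(=O)(=O)c3ccccc3)C[C@@H]2NC(=O)c2cc(-c3ccccc3Cl)on2)C1` differs from compound 2 on a carbonyl carbon: a group of 9 heavy atoms (6 carbon, 2 nitrogen, 1 oxygen; one six-membered non-aromatic ring with 1 hetero atom) in place of a group of 8 heavy atoms (6 carbon, 2 nitrogen; one six-membered non-aromatic ring with 1 hetero atom), on a carbonyl carbon. Among the measured compounds shown here, only one measured step bears on this, a 9.4-fold higher number from compound 1 to compound 2 (0.97 log units; beyond the scatter), a modest move that put methyl in place of hydrogen on an amide-type nitrogen. With so little evidence, a fall of similar or somewhat larger size is expected, and the estimated change is a 7.1-fold lower number from compound 2 to compound 3 (0.85 log units; beyond the scatter). For compound 3 the expected value is 16000 nM, with an estimated range of 3500 nM to 75000 nM.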

Compound 3, solubility: 4500 nM
Estimate against measurement, compound 3: 3.6-fold (0.55 log units) above, within the range that was stated.
By their numbers in this assay, from the lowest: compound 3; then compound 1; then compound 2.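

In this assay this position proves sensitive: the change on the carbonyl carbon gives a 25-fold lower number from compound 2 to compound 3 (1.40 log units; beyond the scatter), larger than the earlier rise and enough to reverse it. The formyl on the ring nitrogen alone gives a 2.7-fold lower number from compound 1 to compound 3 (0.43 log units; beyond the scatter), so it lowers the number even with the amide hydrogen in place, while the larger fall also includes the loss of the methyl on that amide nitrogen. No measurement shown explains either fall.

From the compounds shown here alone, it remains open whether an acetyl group or a longer acyl chain on the ring nitrogen would behave like formyl. Also open, going by these compounds, is whether the methyl on the amide nitrogen would still raise the number with formyl present.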